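A few compounds are considered here, and "the series" means these few. Any claim that something is new, unique, unknown or untested is made for them only; others in the source may bear on it.

Compound 2 `Cc1cc(NC(=O)OCc2ccccc2)nn1Cc1cc(Cl)ccc1OCc1ccccc1` is one of two analogues tested in an assay on CHO-K1 cells for displacement of a labelled ligand from prostaglandin E2 receptor EP1 subtype (Homo sapiens); on this read-out lower numbers stand for stronger inhibition and higher numbers for weaker inhibition. Within the data shown here, compound 2 gives 79.4 nM, and compound 1 `Cc1cc(C(N)=O)nn1Cc1cc(Cl)ccc1OCc1ccccc1` gives 126 nM; the two sit within the scatter of each other, as the only recorded step, a 1.6-fold lower number from compound 1 to compound 2 (0.20 log units; within the scatter), shows. Compound 3 `Cc1cc(NC(=O)OCc2ccccn2)nn1Cc1cc(Cl)ccc1OCc1ccccc1` is not yet measured. It differs from compound 2 by one change: pyridin-2-yl in place of phenyl on a saturated chain carbon bound to an oxygen next to a carbonyl group. Among the measured compounds shown here, no measured step tests this change; the one step recorded concerns a different part of the molecule and was itself within the scatter. Nothing in the data therefore points to a shift beyond the scatter in this assay, in either direction, and compound 3 is expected to give about 80 nM, with a range from 30 nM to 250 nM. The step this estimate implies, a 1.0-fold higher number from compound 2 to compound 3 (0.00 log units; within the scatter), is expected to stay within the scatter.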

Compound 3, half-maximal inhibitory concentration in the prostaglandin E2 receptor EP1 subtype assay: 79.4 nM
Beside the measured number, compound 3's estimate is 1.0-fold (0.00 log units) above it; the range from low to high includes it.
By their numbers in the prostaglandin E2 receptor EP1 subtype assay, from the lowest: compounds 2, 3 and 1 (each within the scatter of the next).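

Among these compounds, in the prostaglandin E2 receptor EP1 subtype assay the result gives the first direct reading of pyridin-2-yl in place of phenyl on a saturated chain carbon bound to an oxygen next to a carbonyl group, and the step shows no readable shift (no change at the digits printed from compound 2 to compound 3 (within the scatter)), with compound 2 at 79.4 nM and compound 3 at 79.4 nM, although the entering ring carries a hydrogen-bond acceptor that the leaving ring lacks. Compound 3 also stays within the scatter of the carbamoyl analogue in the prostaglandin E2 receptor EP1 subtype assay (a 1.6-fold lower number from compound 1 to compound 3 (0.20 log units; within the scatter)), and the same swap leaves the distribution coefficient level in a physicochemical assay for lipophilicity, at pH 7.4; a lower number here means a more polar compound, a higher number a more lipophilic compound (no change at the digits printed from compound 2 to compound 3 (within the scatter)), with compound 2 at 3.1 and compound 3 at 3.1. No available evidence explains why these numbers stay level.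

The compounds shown leave open whether pyridin-3-yl, pyridin-4-yl or a saturated ring bearing an amine would hold the number in the prostaglandin E2 receptor EP1 subtype assay. They also leave open what a longer chain carrying the ring would do.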